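Furan-3-yl for thiophen-2-yl across two cores

This account rests on a few compounds, and the source may have more. Where it says the series, first, only, none or still open, it means among the compounds named here.

Measured so far:
Compound 1 `CSc1ncnc2c1c(-c1ccoc1)cn2[C@@H]1O[C@H](CO)[C@@H](O)[C@H]1O`: 360 nM
Compound 2 `CSc1ncnc2c1c(-c1cccs1)cn2[C@@H]1O[C@H](CO)[C@@H](O)[C@H]1O`: 1130 nM
Compound 3 `Nc1nc(N)c2c(-c3cccs3)cn([C@@H]3O[C@H](CO)[C@@H](O)[C@H]3O)c2n1`: > 20000 nM

In a functional assay on HL-60 cells (Homo sapiens) for antiproliferative activity, read by XTT assay, with a stated time of 72 h (on this read-out higher numbers stand for weaker inhibition and lower numbers for stronger inhibition), compound 1 gives 360 nM and compound 2 gives 1130 nM. The change between them, (furan-3-yl in place of thiophen-2-yl on an aromatic carbon), gave a 3.1-fold lower number from compound 2 to compound 1 (0.50 log units; beyond the scatter).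

Compound 3 reaches only the limit of this assay, > 20000 nM; this is a limit, not a number (the limit of > 20000 nM in this assay, at which 1 of the 3 values shown sits). The difference between the core of compound 3 and the core of compound 2 is not broken down here.

Compound 4 `Nc1nc(N)c2c(-c3ccoc3)cn([C@@H]3O[C@H](CO)[C@@H](O)[C@H]3O)c2n1` is not yet measured. Within the data shown here, it differs from compound 3 by furan-3-yl in place of thiophen-2-yl on an aromatic carbon, the same change as the one from compound 2 to compound 1. For compound 4 the step of an at least 1.3-fold lower number from compound 3 to compound 4 (0.12 log units; that floor lies within the scatter) is expected, resting on a 3.1-fold lower number from compound 2 to compound 1 (0.50 log units; beyond the scatter), though the starting point is a limit and the true value of compound 3 may lie well beyond it. Compound 4 is therefore estimated at 15000 nM in this assay, with a range of 4000 nM to 60000 nM, and a limit rather than a number is a real possibility.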

Compound 4, half-maximal inhibitory concentration: > 20000 nM
Compound 4 ended at the assay's limit; the forecaster's own chance of this, stated with the estimate: 55%; at least 1.3-fold (0.12 log units) between middle value and limit.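

In this assay compound 4 gives > 20000 nM, a limit and not a number. The step from compound 3 to compound 4 cannot be read, because both compounds sit at that limit: the limit of > 20000 nM in this assay, at which 2 of the 4 values shown sit.

Still open, on these data alone, is whether furan-3-yl in place of thiophen-2-yl changes the true value on the core of compound 3 at all.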